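A few compounds are considered here, and "the series" means these few. Any claim that something is new, unique, unknown or untested is made for them only; others in the source may bear on it.

Compound 1 `COc1cc(N)c(Cl)cc1NC(=O)C1CCN(Cc2ccc(Cl)cc2)CC1` gives 1.2 mg/kg in a functional assay on the whole organism for antagonist activity, with Mus musculus as the target; a lower number here means that less compound is needed, a higher number that more compound is needed for the effect. For compound 2 `COc1cc(N)c(Cl)cc1NC(=O)C1CCN(CC2CCC2)CC1` this assay reports only a limit, > 10 mg/kg. Compound 2 therefore has no firm number, only the limit at which it sits. Compound 3 `CCCCN1CCC(C(=O)Nc2cc(Cl)c(N)cc2OC)CC1` differs from compound 2 by propyl in place of cyclobutyl on a saturated chain carbon bound to an amine nitrogen in a ring. For the measured compounds named here, no measured step covers this exact change. Going by the values given here, the one measured step, an at least 8.3-fold higher number from compound 1 to compound 2 (0.92 log units; beyond the scatter), concerns a different swap, yet it shows that a small non-aromatic group on a saturated chain carbon bound to an amine nitrogen in a ring drove the value to the limit of > 10 mg/kg in this assay, at which 1 of the 2 values shown sits. Propyl is another small non-aromatic group, so compound 3 is expected to remain in that weak region, with a fair chance of again returning only a limit. Compound 3 is expected near 12 mg/kg. The range expected for compound 3 runs from 4 mg/kg to 40 mg/kg. The expected step that the limit leaves unreadable from compound 2 to compound 3 is thus estimated to lie within the scatter.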

Compound 3, dose for half-maximal effect: > 10 mg/kg
Compound 3 was reported as a limit; the forecaster's own chance of this, stated with the estimate: 60%; the middle value lies beyond the limit too.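

With propyl in place of 4-chlorophenyl on a saturated chain carbon bound to an amine nitrogen in a ring, this assay shows an at least 8.3-fold higher number from compound 1 to compound 3 (0.92 log units; beyond the scatter). The loss seen with cyclobutyl therefore does not require a four-membered ring, for propyl, which has no ring, ends in the same place: the limit of > 10 mg/kg in this assay, at which 2 of the 3 values shown sit. Compound 2 and compound 3 each carry only a limit, so the step between them cannot be read and neither group can be ranked against the other.

The compounds shown leave open whether the chlorine or the aromatic ring matters for the firm value of compound 1, 1.2 mg/kg. Plain phenyl or 4-fluorophenyl at this place would separate the two, and a pyridine ring would test whether a ring nitrogen is tolerated there.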